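A few compounds are considered here, and "the series" means these few. Any claim that something is new, unique, unknown or untested is made for them only; others in the source may bear on it.

Measured so far in an assay on HeLa cells for binding affinity to Vasopressin V2 receptor (Homo sapiens); on this read-out lower numbers stand for stronger inhibition and higher numbers for weaker inhibition:

Compound 1, `CN(C)c1ccc(C(=O)N2CCCCc3ccccc32)c(Cl)c1`: 18 nM
Compound 2, `CN(C)c1ccc(C(=O)N2CCCCc3cc(Cl)ccc32)c(Cl)c1`: 13 nM
Compound 3, `O=C(c1ccc(N2CCCC2)cc1)N1CCCCc2ccccc21`: 1000 nM

Compounds 1 and 2 share a core and differ in one place: chloro in place of hydrogen on an aromatic carbon. That step gives a 1.4-fold lower number from compound 1 to compound 2 (0.14 log units; within the scatter), so the two values are not separated in this assay. Compound 3 has a different core; how it differs from compound 1 is not broken down here. Compound 3 gives the highest number of the three, and its gap to compound 1 and to compound 2 lies well beyond the scatter in both cases.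

Compound 4, `O=C(c1ccc(N2CCCC2)cc1)N1CCCCc2cc(Cl)ccc21`, is not yet measured. It relates to compound 3 as compound 2 relates to compound 1: chloro in place of hydrogen on an aromatic carbon. The two changes are described in the same words, at the same kind of place, so the change is the same one made on the second core. Within this set it occurs twice in all, once measured and once open.

Within the data shown here, the only measured instance of this change, from compound 1 to compound 2, stayed within the scatter. On that basis compound 4 is expected to sit close to compound 3, with an estimated step of a 1.3-fold lower number from compound 3 to compound 4 (0.12 log units; within the scatter), resting on the measured 1.4-fold lower number from compound 1 to compound 2 (0.14 log units; within the scatter). For compound 4 the estimate in this assay is 750 nM, with a range from 350 nM to 1600 nM.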

Compound 4, half-maximal inhibitory concentration: 210 nM
Estimate against measurement, compound 4: 3.6-fold (0.55 log units) above, and the stated range ends above it.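

In this assay, chloro in place of hydrogen on an aromatic carbon gives a 4.8-fold lower number from compound 3 to compound 4 (0.68 log units; beyond the scatter), a modest step that stands clear of the scatter, whereas the same change on the other core gives a 1.4-fold lower number from compound 1 to compound 2 (0.14 log units; within the scatter). Both steps run towards a lower number, but their size does not carry over from one core to the other: the same change on two cores in this assay, a 1.4-fold lower number (0.14 log units; within the scatter) from compound 1 to compound 2 and a 4.8-fold lower number (0.68 log units; beyond the scatter) from compound 3 to compound 4, 3.4-fold (0.54 log units) apart, beyond the scatter of two such steps. This shows that a step measured on one core is a poor guide to its size on the other in this series; with a single pair on each core, it does not show what sets the size of the step, and it gives no general rule for the change on further cores.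

Which of the differences between the two cores goes with the larger step stays open, as does whether a third core would give a step nearer the smaller or the larger one. Also open, from the compounds shown here alone, is whether another group at the same aromatic carbon, such as fluoro, methoxy or a carboxylic acid, would show the same dependence on the core as chloro does.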